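Propyl for hydroxy on two related cores

The source may hold more compounds than are shown below. What is called first, only, known or untested is meant among the compounds shown, and "the series" means these compounds.

Measured so far:
compound 1 `Cc1cc(=O)oc2c1c(C)nn2CCO`: 100 mg/kg
compound 2 `CCCCCn1nc2oc(=O)cc(C)c2c1C`: 60.6 mg/kg
compound 3 `Cc1cc(=O)oc2nn(CCO)c(C)c12`: > 100 mg/kg

In a functional assay on the whole organism with Mus musculus as the target, in the writhing test (a higher number here means that more compound is needed for the effect, a lower number that less compound is needed), compound 1 gives 100 mg/kg and compound 2 gives 60.6 mg/kg; the two numbers lie within the scatter of each other. Compound 3 reaches only a limit of the assay, > 100 mg/kg. That is the limit recorded as the limit of > 100 mg/kg in this assay, at which 1 of the 3 values shown sits. Compound 1 and compound 3 are built from the same atoms joined differently; the difference between the two cores is not broken down here. The change propyl in place of hydroxy on a saturated chain carbon, two bonds along the chain from an aromatic nitrogen gives the step of an at least 1.6-fold lower number from compound 3 to compound 2 (0.21 log units; that floor lies within the scatter). The same change, (propyl in place of hydroxy on a saturated chain carbon, two bonds along the chain from an aromatic nitrogen), leads to compound 4 `CCCCCn1nc(C)c2c(C)cc(=O)oc21`, not yet measured. For compound 4 a step of a 1.7-fold lower number from compound 1 to compound 4 (0.22 log units; within the scatter) is expected, resting on an at least 1.6-fold lower number from compound 3 to compound 2 (0.21 log units; that floor lies within the scatter). Compound 4 is therefore estimated at 60 mg/kg, likely between 30 mg/kg and 120 mg/kg.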

Compound 4, dose for half-maximal effect: > 100 mg/kg
Compound 4: no number, only a limit; the forecaster's own chance of this, stated with the estimate: 10%; middle value at least 1.6-fold (0.22 log units) away from the limit.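

In this assay compound 4 gives > 100 mg/kg as a limit of the assay, not a number. The new step reads a number no lower from compound 1 to compound 4 (the limit leaves the size open) and its size cannot be read, so the notes can say neither that propyl in place of hydroxy carries over from one core to the other nor that it fails to: the same change on two cores in this assay, an at least 1.6-fold lower number (0.21 log units; that floor lies within the scatter) from compound 3 to compound 2 and a number no lower (the limit leaves the size open) from compound 1 to compound 4; the limit leaves it open whether they differ
What is shown is only that this change gives no readable number on the core of compound 1, and no gain on that core is established.

Open, on these data alone, is whether an amine or a carboxylic acid in place of the hydroxy, or a chain longer than pentyl, gives a readable number on either core. Any such comparison is limited by how many values already sit at the limit: the limit of > 100 mg/kg in this assay, at which 2 of the 4 values shown sit.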